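Replacing the 2-methoxyethoxy chain of compound 2 with isopropoxy

A few compounds are considered here, and "the series" means these few. Any claim that something is new, unique, unknown or untested is made for them only; others in the source may bear on it.

Measured compounds:
compound 1, `CCCCOc1cc(-c2cc3c(O)nc(C)nc3cc2C(C)C)ccc1Cl`, 82 nM
compound 2, `COCCOc1cc(-c2cc3c(O)nc(C)nc3cc2C(C)C)ccc1Cl`, 216 nM

In a functional assay for inhibition of transient receptor potential cation channel subfamily V member 1 (Homo sapiens), read by fluorescence and calcium flux (a lower number here means a stronger inhibitor, a higher number a weaker inhibitor), compound 2 gives 216 nM, the higher of the two numbers shown; its only measured neighbour is compound 1 with 82 nM, and the step of a 2.6-fold higher number from compound 1 to compound 2 (0.42 log units; beyond the scatter) lies beyond the scatter. Compound 3, `Cc1nc(O)c2cc(-c3ccc(Cl)c(OC(C)C)c3)c(C(C)C)cc2n1`, carries the change (isopropyl in place of 2-methoxyethyl on an oxygen on an aromatic ring). For the measured compounds named here, the one measured step that bears on it is a 2.6-fold higher number from compound 1 to compound 2 (0.42 log units; beyond the scatter), in which a chain without the oxygen acceptor gave the lower number. Compound 3 likewise drops that acceptor, though its chain is shorter than that of compound 1, so the expectation rests only on that single step. Compound 3 is therefore expected to move by a 2.0-fold lower number from compound 2 to compound 3 (0.29 log units; within the scatter), toward a stronger inhibitor, with a modest step. The estimate for compound 3 is 110 nM, within a range of 45 nM to 280 nM.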

Compound 3, half-maximal inhibitory concentration: 201 nM
Compound 3: middle estimate off by 1.8-fold (0.26 log units), on the low side, and the stated range covers the measured number.
By their numbers in this assay, from the lowest: compound 1; then compounds 3 and 2 (each within the scatter of the next).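

In this assay the change from 2-methoxyethyl to isopropyl on the oxygen on the aromatic ring, a 1.1-fold lower number from compound 2 to compound 3 (0.03 log units; within the scatter), leaves the number within the scatter, so a chain without the oxygen of 2-methoxyethyl does not by itself match compound 1. Isopropyl and butyl on that same oxygen stay apart, a 2.5-fold higher number from compound 1 to compound 3 (0.39 log units; beyond the scatter), which makes compound 1 the strongest inhibitor of the three and shows that the gap seen for the 2-methoxyethyl chain is not tied to that chain's oxygen alone. No independent measurement here explains why these chains differ.

Going by these compounds, it remains open whether the lower number belongs to straight chains in general or to butyl in particular, which a propyl or pentyl chain on the same oxygen would help to separate. On these data alone, how a chain ending in an amine or a carboxylic acid would read in this assay also remains unknown.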